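Swapping Trifluoromethyl for Cyclobutyl on a Pyridine Ring

The source may report more compounds than this note shows. Statements on the series, on what has been measured and on what is new or still open speak of the compounds shown alone.

In an assay on HBE cells for positive allosteric modulation of Cystic fibrosis transmembrane conductance regulator variant F508del (Homo sapiens) (on this read-out lower numbers stand for smaller maximal responses and higher numbers for larger maximal responses), the two measured compounds gave these numbers: compound 1 `COc1ccc(Cl)cc1CN[C@H]1[C@H](C(C)(C)C)[C@@H](C(=O)O)N(C(=O)C2CCCCC2)[C@H]1c1ccccc1` reached 109%, and compound 2 `COc1ncc(C(F)(F)F)cc1CN[C@H]1[C@H](C(C)(C)C)[C@@H](C(=O)O)N(C(=O)C2CCCCC2)[C@H]1c1ccccc1` reached 85%.

Compound 2 therefore holds the lower of the two numbers in this assay. Among the compounds with values here, the one measured step, a number 24 percentage points lower from compound 1 to compound 2 (beyond the scatter), replaced the whole aromatic group on the chain carbon next to the amine nitrogen, so it does not isolate any single substituent.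

Compound 3 `COc1ncc(C2CCC2)cc1CN[C@H]1[C@H](C(C)(C)C)[C@@H](C(=O)O)N(C(=O)C2CCCCC2)[C@H]1c1ccccc1` keeps everything in compound 2 except one group: cyclobutyl in place of trifluoromethyl on an aromatic carbon. The entering group has the same number of heavy atoms as the leaving one and carries no donors, acceptors or charge.

Within the data shown here, only the step from compound 1 to compound 2 bears on this change, and it bears only loosely, since it altered the ring and its substituent together. Among the measured compounds shown here, no measured pair shows a trifluoromethyl-to-cyclobutyl swap by itself. The expected step is therefore modest, a number 5 percentage points higher from compound 2 to compound 3 (within the scatter), in either direction or none beyond the scatter. Compound 3 is estimated to reach 90% in this assay, within a range of 68% to 115%.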

Compound 3, largest response reached (reported as percent of maximum), in percent of the reference or control that the assay uses: 106%
Estimate against measurement, compound 3: 16 percentage points below; measured number inside the range.
By their numbers in this assay, from the lowest: compound 2; then compounds 3 and 1 (each within the scatter of the next).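

In this assay, within the data shown here, this is the first step that changes only the group on this aromatic carbon, para to a methoxy group: a number 21 percentage points higher from compound 2 to compound 3 (beyond the scatter). The response at this position therefore depends on which group sits there, even though trifluoromethyl and cyclobutyl have the same count of heavy atoms and neither has hydrogen-bond donors or acceptors. The other step, a number 3 percentage points lower from compound 1 to compound 3 (within the scatter), shows that 5-cyclobutyl-2-methoxypyridin-3-yl and 5-chloro-2-methoxyphenyl cannot be told apart on this read-out, so the lower number seen with 2-methoxy-5-(trifluoromethyl)pyridin-3-yl does not hold for every group built on this pyridine. Nothing available here explains why cyclobutyl and trifluoromethyl differ in this way.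

Among these compounds, with only two groups compared on this carbon, no trend can be drawn from them, and a cyclopropyl, an isopropyl or a nitrile there could fall anywhere relative to compound 2 and compound 3. On these data alone, it also remains open whether a chlorine on this same pyridine would match the chlorine of compound 1, which would separate the effect of the ring nitrogen from that of the substituent.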